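The compounds below may be only part of what the source reports. "The series", "measured", "known", "first", "only" and "open" are said of these compounds alone.

Series notes. Compound 1 `CN(c1ccnc(Nc2ccc(C#N)cc2)n1)c1c(F)cc(-c2ccc(C#N)cc2)cc1F` and compound 2 `CCCN(c1ccnc(Nc2ccc(C#N)cc2)n1)c1c(F)cc(-c2ccc(C#N)cc2)cc1F` share the core, differing only in the chain on the ring nitrogen. In an ADME assay on MT4 cells (Homo sapiens) for cytotoxicity, read by MTT assay, with a stated time of 5 days (on this read-out higher numbers stand for lower toxicity in this test and lower numbers for higher toxicity in this test), compound 1 gives 148000 nM, and in this assay compound 2 gives 212000 nM. Among the measured compounds shown here, the one step between them, ethyl in place of hydrogen on a saturated chain carbon bound to a nitrogen on an aromatic ring, reads a 1.4-fold higher number from compound 1 to compound 2 (0.16 log units; within the scatter). Compound 2 thus holds the higher of the two numbers, but its separation from compound 1 is within the scatter, so no order between the two is claimed.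

Compound 3 `CCCCN(c1ccnc(Nc2ccc(C#N)cc2)n1)c1c(F)cc(-c2ccc(C#N)cc2)cc1F` extends the same chain: methyl in place of hydrogen on a saturated chain carbon, three bonds along the chain from a nitrogen on an aromatic ring. For the measured compounds named here, the only measured step that bears on this change is a 1.4-fold higher number from compound 1 to compound 2 (0.16 log units; within the scatter), which was small; the two chain lengthenings are not the same change, but nothing among the measured compounds points to a step beyond the scatter in this assay. The expected step from compound 2 to compound 3 is therefore a 1.0-fold higher number from compound 2 to compound 3 (0.02 log units; within the scatter), in no firm direction. On that basis compound 3 is estimated at 220000 nM in this assay, within a range of 110000 nM to 440000 nM.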

Compound 3, half-maximal cytotoxic concentration: 211000 nM
Beside the measured number, compound 3's estimate is 1.0-fold (0.02 log units) above it; measured number inside the range.
By their numbers in this assay, from the lowest: compounds 1, 3 and 2 (each within the scatter of the next).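

Among the compounds shown here, the methyl added three bonds along the chain, which turns propyl into butyl, gives a 1.0-fold lower number from compound 2 to compound 3 (0.00 log units; within the scatter) in this assay and extends the small effect of chain length to a site on the chain that the earlier compounds did not test. Measured against the shortest chain, the butyl chain gives a 1.4-fold higher number from compound 1 to compound 3 (0.15 log units; within the scatter) and so also stays within the scatter, which means that the methyl, propyl and butyl members of the series cannot be put in any order in this assay and that no trend with chain length can be claimed. No supporting data are available to explain why these numbers lie so close together.

Going by these compounds, it remains open whether a longer chain such as octyl would keep the number within the scatter of these three compounds. On these data alone, it is equally open whether a chain ending in an amine or a carboxylic acid, or a cyclopropyl group on the same nitrogen, would do so.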